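The source may hold more compounds than are shown below. What is called first, only, known or untested is meant among the compounds shown, and "the series" means these compounds.

Working notes on the series. Compound 1 `CCOC(=O)c1cnc(C(C)(C)C)nc1NN1C(=O)C=C(C)C1=O` gives 1000 nM in a functional assay on Jurkat cells for inhibition of nuclear factor NF-kappa-B complex (Homo sapiens); on this read-out lower numbers stand for stronger inhibition and higher numbers for weaker inhibition; compound 3 `CCOC(=O)c1cnc(C2CC2)nc1NN1C(=O)C=C(C)C1=O` gives 1000 nM, and the pair shows no change at the digits printed from compound 1 to compound 3 (within the scatter). Compound 2 `CCOC(=O)c1cnc(-n2nc(C)cc2C)nc1NN1C(=O)C=C(C)C1=O` gives 10000 nM, the highest of the three numbers, with a 10-fold higher number from compound 1 to compound 2 (1.00 log units; beyond the scatter) and a 10-fold lower number from compound 2 to compound 3 (1.00 log units; beyond the scatter) marking its distance from both neighbours.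

Compound 4 `CCOC(=O)c1cnc(CC2=CCCCC2)nc1NN1C(=O)C=C(C)C1=O` is not yet measured. The change from compound 2 is (cyclohex-1-en-1-yl)methyl in place of 3,5-dimethyl-1H-pyrazol-1-yl on an aromatic carbon. Both earlier steps away from the 3,5-dimethyl-1H-pyrazol-1-yl group, to tert-butyl and to cyclopropyl, gave a lower number, so a lower number is also expected here; the step is expected as a 6.7-fold lower number from compound 2 to compound 4 (0.82 log units; beyond the scatter). For compound 4 the estimate is 1500 nM, with a range from 400 nM to 6000 nM.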

Compound 4, half-maximal inhibitory concentration: 2000 nM
For compound 4 the middle estimate is 1.3-fold (0.12 log units) below the measured one; measured number inside the range.
By their numbers in this assay, from the lowest: compounds 1, 3 and 4 (each within the scatter of the next); then compound 2.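

At the position between two ring nitrogen atoms, the all-carbon (cyclohex-1-en-1-yl)methyl group also gives a lower number than the 3,5-dimethyl-1H-pyrazol-1-yl group (a 5.0-fold lower number from compound 2 to compound 4 (0.70 log units; beyond the scatter)). It stays within the scatter of both tert-butyl (a 2.0-fold higher number from compound 1 to compound 4 (0.30 log units; within the scatter)) and cyclopropyl (a 2.0-fold higher number from compound 3 to compound 4 (0.30 log units; within the scatter)), so three all-carbon groups of different shape now sit together, and only compound 2 stands apart. No supporting data explain this separation.

The compounds shown leave open whether the weaker result of compound 2 follows from its ring nitrogen atoms or from its aromatic ring, which a phenyl group here could help separate. They also leave open how an amine such as morpholine would behave at this position.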